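The source may hold more compounds than are shown below. What is called first, only, known or untested is meant among the compounds shown, and "the series" means these compounds.

Of the compounds shown here, three that share one core have been measured in an assay on HEK293 cells for displacement of a labelled ligand from 5-hydroxytryptamine receptor 7 (Rattus norvegicus), with a stated time of 60 min; a higher number here means a weaker inhibitor, a lower number a stronger inhibitor. Compound 1 `c1ccc(Cn2cc(-c3ccccc3)c3c2CCNC3)cc1` gives 220 nM. Compound 2 `Clc1ccccc1Cn1cc(-c2ccccc2)c2c1CCNC2` gives 22900 nM, and compound 3 `Clc1cccc(Cn2cc(-c3ccccc3)c3c2CCNC3)c1` gives 6600 nM. Putting a chloro onto the ring weakens binding markedly in both cases: a 100-fold higher number from compound 1 to compound 2 (2.02 log units; beyond the scatter) and a 30-fold higher number from compound 1 to compound 3 (1.48 log units; beyond the scatter). Between the two chloro compounds the gap is smaller: a 3.5-fold lower number from compound 2 to compound 3 (0.54 log units; beyond the scatter). Compound 3 thus stands second highest of the three numbers, well above compound 1 and somewhat below compound 2.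

Compound 4 `Clc1ccc(Cn2cc(-c3ccccc3)c3c2CCNC3)cc1` has not yet been measured. It differs from compound 3 in one place: 4-chlorophenyl in place of 3-chlorophenyl on a saturated chain carbon bound to an aromatic nitrogen. For the measured compounds named here, no measured step covers this exact change. The nearest guide is the step from compound 2 to compound 3, where the chloro changed its place on the ring and the number fell modestly, while compound 1 shows that the core without any chloro sits far lower still. A further modest lowering is expected, a 2.2-fold lower number from compound 3 to compound 4 (0.34 log units; beyond the scatter). Compound 4 is therefore estimated at 3000 nM, with a range from 600 nM to 15000 nM.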

Compound 4, inhibition constant: 753 nM
Beside the measured number, compound 4's estimate is 4.0-fold (0.60 log units) above it, and the stated range covers the measured number.
By their numbers in this assay, from the lowest: compound 1; then compound 4; then compound 3; then compound 2.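

Where the chloro sits turns out to matter far more than the earlier compounds showed, with an 8.8-fold lower number from compound 3 to compound 4 (0.94 log units; beyond the scatter) and a 30-fold lower number from compound 2 to compound 4 (1.48 log units; beyond the scatter) in this assay when only its place on the ring changes. Of the three chlorophenyl compounds, compound 4 comes closest to compound 1 with its unsubstituted ring, yet adding the chloro still has a cost, with a 3.4-fold higher number from compound 1 to compound 4 (0.53 log units; beyond the scatter) remaining. No measurement is available that explains why this one change of place has so large an effect.

The compounds shown leave open whether this order of ring places holds only for chloro or also for another group, such as fluoro or methoxy. They also leave open whether any group on that ring can match or improve on the unsubstituted ring of compound 1.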